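A few compounds are considered here, and "the series" means these few. Any claim that something is new, unique, unknown or untested is made for them only; others in the source may bear on it.

Measured so far in an ADME assay on MRC5 cells (Homo sapiens) for cytotoxicity, read by fluorescence and resazurin assay, with a stated time of 3 days (a higher number here means that more compound is needed for the effect, a lower number that less compound is needed), are these compounds
compound 1 `CCOC(=O)Nc1ccc(S(=O)(=O)n2c(C3(O)C=CC(=O)C=C3)cc3ccccc32)cc1` gives 86 nM
compound 2 `CN1CCN(C(=O)CCc2ccc(S(=O)(=O)n3c(C4(O)C=CC(=O)C=C4)cc4ccccc43)cc2)CC1` gives 52 nM
compound 3 `CN1CCN(CCCc2ccc(S(=O)(=O)n3c(C4(O)C=CC(=O)C=C4)cc4ccccc43)cc2)CC1` gives 50 nM

Compound 3 (50 nM) lies within the scatter of both other compounds. Compound 4 `O=C1C=CC(O)(c2cc3ccccc3n2S(=O)(=O)c2ccc(CCC(=O)O)cc2)C=C1` differs from it by carboxy in place of (4-methylpiperazin-1-yl)methyl on a saturated chain carbon, two bonds along the chain from an aromatic carbon. Among the compounds with values here, no measured compound carries carboxy, so no measured step makes this change. The closest evidence is a 1.7-fold lower number from compound 1 to compound 3 (0.24 log units; within the scatter) and a 1.0-fold lower number from compound 2 to compound 3 (0.02 log units; within the scatter) together with a 1.7-fold lower number from compound 1 to compound 2 (0.22 log units; within the scatter), and all three stay within the scatter. No step beyond the scatter is therefore expected in this assay, though the range must stay wide. The estimate implies a 1.8-fold higher number from compound 3 to compound 4 (0.26 log units; within the scatter) as the expected step. For compound 4 the estimated value is 90 nM with an expected range from 30 nM to 350 nM in this assay here.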

Compound 4, half-maximal effective concentration: 3300 nM
Beside the measured number, compound 4's estimate is 37-fold (1.56 log units) below it, outside the stated range (above it).
By their numbers in this assay, from the lowest: compounds 3, 2 and 1 (each within the scatter of the next); then compound 4.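

In this assay the carboxy group gives the first large steps seen at this position: a 66-fold higher number from compound 3 to compound 4 (1.82 log units; beyond the scatter) and a 63-fold higher number from compound 2 to compound 4 (1.80 log units; beyond the scatter) and a 38-fold higher number from compound 1 to compound 4 (1.58 log units; beyond the scatter). The earlier compounds, all within the scatter of one another, had not shown that a change in this side chain could move the number so far. No measured evidence here accounts for this result. Going by these compounds, it remains open whether the step follows the carboxy group itself or the loss of the 4-methylpiperazin-1-yl group. A methyl ester or a dimethylamino group on the same chain would separate these two readings.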